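The source may report more compounds than this note shows. Statements on the series, on what has been measured and on what is new or still open speak of the compounds shown alone.

Measured so far:
Compound 1 `NC(=O)c1ccc(Cn2ncc3c(Nc4ccc(OC(F)(F)F)cc4)ncnc32)cc1` gives > 10000 nM in an ADME assay on BaF3 cells (Mus musculus) for cytotoxicity; on this read-out higher numbers stand for an effect only at larger amounts of compound and lower numbers for an effect already at smaller amounts; this is a limit of the assay, not a number.
Compound 2 `Cc1ccc(NC(=O)c2cccc(C(F)(F)F)c2)cc1C(=O)c1cc2c(Nc3ccc(OC(F)(F)F)cc3)ncnc2s1` gives 8900 nM in this assay.
Compound 3 `NC(=O)c1cccc(Nc2cc(Nc3ccc(OC(F)(F)F)cc3)ncn2)c1` gives > 10000 nM in this assay, again a limit of the assay rather than a number.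

Compound 1 therefore stands at the limit of this assay, as the shown evidence records: the limit of > 10000 nM in this assay, at which 2 of the 3 values shown sit. Going by the values given here, compound 2 sits near that limit as well, so the three measured compounds give no step between them that could be read as a trend.

Compound 4 `CC(C)(C)n1ncc2c(Nc3ccc(OC(F)(F)F)cc3)ncnc21` has not yet been measured in this assay. It differs from compound 1 in one place: tert-butyl in place of 4-carbamoylbenzyl on an aromatic nitrogen.

Among the compounds with values here, no measured pair shows what such a change does in this assay, so the expectation rests on compound 1 alone, which gives > 10000 nM as a limit. The step of an at least 1.1-fold lower number from compound 1 to compound 4 (0.04 log units; that floor lies within the scatter) is expected to stay within the usual scatter, in no clear direction. Compound 4 is thus estimated at 9000 nM in this assay, with a range from 2500 nM to 30000 nM, and a sizeable chance that only a limit is reported again.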

Compound 4, half-maximal effective concentration: 7300 nM
Beside the measured number, compound 4's estimate is 1.2-fold (0.09 log units) above it, within the range that was stated.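

With tert-butyl in place of 4-carbamoylbenzyl on this aromatic nitrogen, the study gains its first pair differing in one place in this assay, and the change reads as an at least 1.3-fold lower number from compound 1 to compound 4 (0.13 log units; that floor lies within the scatter). Because compound 1 carries only a limit of the assay, the step has a floor but no known full size: the limit of > 10000 nM in this assay, at which 2 of the 4 values shown sit. At this position, then, a group with no ring and no hydrogen-bond donor or acceptor gives a readable number, although the step cannot be said to lie beyond the scatter.

The compounds shown leave open whether the carbon ring or the carbamoyl part of the departing group matters on this nitrogen. A plain benzyl, or a carboxylic acid in place of the carbamoyl group, would separate the two, while a longer alkyl chain would test the size of the group.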